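The source may hold more compounds than are shown below. What is called first, only, known or untested is meant among the compounds shown, and "the series" means these compounds.

Compound 1 `COc1c(N2CCN(C(=O)C3COc4ccccc4O3)CC2)c(F)cc2c(=O)c(C(=O)O)cn(C3CC3)c12` was tested in an ADME assay on Vero cells (Chlorocebus sabaeus) for cytotoxicity, read by MTT assay, with a stated time of 72 h (a higher number here means a weaker inhibitor, a lower number a stronger inhibitor), where compound 1 gives 119000 nM. Compound 2 `COc1c(N2CCN(C)C(c3ccccc3)C2)c(F)c([N+](=O)[O-])c2c(=O)c(C(=O)O)cn(C3CC3)c12` was measured in the same way, and in this assay compound 2 gives 126000 nM. Of the two numbers compound 1 has the lower one, but the gap to compound 2 is within the scatter, so the two are best read as the same. Compound 3 `COc1c(N2CCN(C(=O)C3COc4ccccc4O3)CC2)c(F)c([N+](=O)[O-])c2c(=O)c(C(=O)O)cn(C3CC3)c12` has not yet been measured in this assay. It differs from compound 1 in one place: nitro in place of hydrogen on an aromatic carbon. Among the compounds with values here, no step between measured compounds isolates this change, yet the nitro-bearing compound 2 already sits beside compound 1. For compound 3 the step from compound 1 is expected to be none beyond the scatter, a 1.0-fold higher number from compound 1 to compound 3 (0.00 log units; within the scatter), because the nitro-bearing compound 2 gives 126000 nM. Compound 3 is therefore expected to give about 120000 nM, with a range from 60000 nM to 240000 nM.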

Compound 3, half-maximal inhibitory concentration: 110000 nM
The estimate for compound 3 lay 1.1-fold (0.04 log units) above the measured number, and the stated range covers the measured number.
By their numbers in this assay, from the lowest: compounds 3, 1 and 2 (each within the scatter of the next).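

Compound 2 also carries the nitro group, but it differs from compound 1 in more than one place, so it could not isolate this change. The pair of compound 1 and compound 3 does: in this assay, nitro in place of hydrogen on this aromatic carbon, ortho to a fluoro group and para to a methoxy group, gives a 1.1-fold lower number from compound 1 to compound 3 (0.03 log units; within the scatter), so at this position and with this large group the added nitro leaves no reading that can be told from repeat-measurement noise. Nothing measured here bears on why the result comes out this way. As far as these compounds go, whether an amino group, a nitrile or a chlorine atom on the same carbon would also stay within the scatter remains open. So does whether nitro would behave alike with a different large group on the shared core.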